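Swapping a nitrothiazole for a pyridine on the amide

This account rests on a few compounds, and the source may have more. Where it says the series, first, only, none or still open, it means among the compounds named here.

Compound 2 `O=C(COc1ccc(/C=C2\SC(=O)NC2=O)cc1)Nc1ncc([N+](=O)[O-])s1` was tested in a functional assay on KB cells (Homo sapiens) for cytotoxicity, read by sulforhodamine B assay, with a stated time of 48 h; a higher number here means a weaker inhibitor of growth, a lower number a stronger inhibitor of growth. In this assay compound 2 gives only a limit of < 100000 nM. Its neighbour compound 1 `O=C(COc1ccc(/C=C2\SC(=O)NC2=O)cc1)Nc1nc2ccccc2s1` likewise gives only a limit of < 100000 nM in this assay. The step that the two limits leave unreadable from compound 1 to compound 2 is therefore not readable, because both values sit at the limit of < 100000 nM in this assay, at which 2 of the 2 values shown sit. Compound 3 `O=C(COc1ccc(/C=C2\SC(=O)NC2=O)cc1)Nc1ccccn1` differs from compound 2 by pyridin-2-yl in place of 5-nitro-1,3-thiazol-2-yl on an amide-type nitrogen. Going by the values given here, no measured step tells how such a change moves the number, so no direction beyond the scatter can be expected. Compound 3 is expected to give 50000 nM, within 10000 nM to 100000 nM, a step that the limit leaves unreadable from compound 2 to compound 3, most likely again reported only as a limit.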

Compound 3, concentration for 50% growth inhibition: < 100000 nM
Compound 3 was reported as a limit; the forecaster's own chance of this, stated with the estimate: 70%; the middle value does not contradict the limit.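

No step can be read among compound 1, compound 2 and compound 3, because each is reported only as a limit: the limit of < 100000 nM in this assay, at which 3 of the 3 values shown sit.

The compounds shown leave open how strongly each inhibits growth, and whether the group on the amide-type nitrogen changes that.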